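The compounds below may be only part of what the source reports. "The series", "measured", "known", "first", "only" and "open" are said of these compounds alone.

Compound 2 `C=C(Br)C(=O)Nc1cccc(/C=C2\SC(=O)N(Cc3cccc(F)c3)C2=O)c1` is the reference point here. In a functional assay on HeLa cells (Homo sapiens) for cytotoxicity, read by cell counting, with a stated time of 4 days (a higher number here means a weaker inhibitor, a lower number a stronger inhibitor), compound 2 gives 2700 nM, the lowest of the two numbers on hand. The closest neighbour is compound 1 `C=C(Br)C(=O)Nc1ccc(/C=C2\SC(=O)N(Cc3ccc(C)cc3)C2=O)cc1`, which in this assay gives 8900 nM, a higher number than compound 2 and beyond the usual scatter. Compound 3 `Nc1cccc(/C=C2\SC(=O)N(Cc3cccc(F)c3)C2=O)c1` carries only a limit of the assay: in this assay compound 3 gives > 250000 nM, which is a limit and not a number. Among the measured compounds shown here, the one measured step, an at least 92-fold higher number from compound 2 to compound 3 (1.96 log units; beyond the scatter), shows that removing the (1-bromoethenyl)carbonyl from the aromatic nitrogen costs a great deal of potency, and this rests on (the limit of > 250000 nM in this assay, at which 1 of the 3 values shown sits).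

Compound 4 `C=C(Br)C(=O)Nc1cccc(/C=C2\SC(=O)N(Cc3ccccc3)C2=O)c1` differs from compound 2 by hydrogen in place of fluoro on an aromatic carbon. For the measured compounds named here, none of the measured steps touches this part of the molecule: the step from compound 2 to compound 3 concerns the amide, and the pair of compound 1 and compound 2 changes two places at once. With nothing pointing either way, the account expects a step in this assay that stays within the scatter, a 1.3-fold higher number from compound 2 to compound 4 (0.11 log units; within the scatter). For compound 4 the estimate in this assay is therefore 3500 nM, between 1200 nM and 10000 nM.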

Compound 4, half-maximal inhibitory concentration: 1400 nM
Estimate against measurement, compound 4: 2.5-fold (0.40 log units) above; measured number inside the range.
By their numbers in this assay, from the lowest: compounds 4 and 2 (each within the scatter of the next); then compound 1. At a limit, above all of these: compound 3.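

In this assay, going from 3-fluorobenzyl to phenyl-bearing benzyl gives a 1.9-fold lower number from compound 2 to compound 4 (0.29 log units; within the scatter), so on this evidence the fluoro can be replaced by hydrogen without a difference the assay can resolve. Among the compounds shown here, this is the first reading on this part of the molecule: the earlier step concerned the amide, whereas here the (1-bromoethenyl)carbonyl stays in place and compound 2 and compound 4 cannot be told apart, which leaves the aromatic ring of the benzyl group, at least for this small change, as a place where the assay shows no sensitivity. Nothing measured here gives a reason for this outcome at the fluoro position.

The compounds shown leave open whether a larger or charged group at this place, such as methoxy, trifluoromethyl, an amine or a carboxylic acid, would be tolerated as well as hydrogen and fluoro are. Compound 1 does carry a methyl on its benzyl group, but it differs from compound 2 in two places at once, so it gives no separate reading of that group.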